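Swapping a Long Alkyl Chain for a Short Ether

This account rests on a few compounds, and the source may have more. Where it says the series, first, only, none or still open, it means among the compounds named here.

Measured so far:
compound 1 `CCCCCCCCCCn1c(N2CCN(C)CC2)nc2ccccc21`: 4200 nM
compound 2 `CCOCCn1c(N2CCNCC2)nc2ccccc21`: 11 nM

In a functional assay on ileum for inhibition of histamine H1 receptor (Cavia porcellus) (on this read-out lower numbers stand for stronger inhibition and higher numbers for weaker inhibition), compound 1 gives 4200 nM, the higher of the two numbers; compound 2 gives 11 nM, a gap far beyond the scatter. Compound 3 `COCCn1c(N2CCN(C)CC2)nc2ccccc21` differs from compound 1 in one place: methoxy in place of octyl on a saturated chain carbon, two bonds along the chain from an aromatic nitrogen. Within the data shown here, no measured pair isolates this change, so its size must be judged. Because compound 2, carrying a short ether chain on the shared core, reaches 11 nM, compound 3 is expected to shift strongly toward lower numbers, roughly a 110-fold lower number from compound 1 to compound 3 (2.02 log units; beyond the scatter). For compound 3 the estimate in this assay is 40 nM, expected between 8 nM and 250 nM.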

Compound 3, half-maximal inhibitory concentration: 13 nM
Compound 3: the middle estimate sits 3.1-fold (0.49 log units) above what was measured; low and high end bracket the measured number.
By their numbers in this assay, from the lowest: compounds 2 and 3 (each within the scatter of the next); then compound 1.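

With the rest of the molecule unchanged, this assay shows a 320-fold lower number from compound 1 to compound 3 (2.51 log units; beyond the scatter) when methoxy takes the place of octyl. This position, on a saturated chain carbon two bonds along the chain from an aromatic nitrogen, therefore has a strong bearing on the read-out, and a single change here is enough to move it far beyond the scatter. Nothing available explains why the number falls. Still open, on these data alone, is whether the step comes from the oxygen or from the smaller group alone. A plain ethyl or butyl chain on the shared core would separate the two, and an amine at the chain end would test other atoms there.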